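The compounds below may be only part of what the source reports. "The series", "measured", "known", "first", "only" and "open" are said of these compounds alone.

In an assay on isolated protein for inhibition of thymidine kinase, cytosolic (Homo sapiens) (on this read-out lower numbers stand for stronger inhibition and higher numbers for weaker inhibition), compound 2 `Cc1cn(C/C=C\CNCc2ccccc2)c(=O)[nH]c1=O` gives 57000 nM, the highest of the two numbers seen so far. Its nearest neighbour is compound 1 `Cc1cn(C/C=C\CNC(=O)c2cccc(C(F)(F)F)c2)c(=O)[nH]c1=O`, which in this assay gives 28000 nM, a lower number lying beyond the scatter. Compound 3 `Cc1cn(C/C=C\CN(Cc2ccccc2)Cc2ccccc2)c(=O)[nH]c1=O` differs from compound 2 by benzyl in place of hydrogen on an amine nitrogen. For the measured compounds named here, no measured pair shows this change, so nothing here fixes its size or direction; the expected step is a 1.1-fold lower number from compound 2 to compound 3 (0.06 log units; within the scatter), which amounts to no shift beyond the scatter. Compound 3 is therefore estimated at 50000 nM, with a range from 15000 nM to 150000 nM.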

Compound 3, half-maximal inhibitory concentration: 3500 nM
Beside the measured number, compound 3's estimate is 14-fold (1.15 log units) above it; the measured number lies below the stated range.
By their numbers in this assay, from the lowest: compound 3; then compound 1; then compound 2.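

On this amine nitrogen, a second benzyl in place of hydrogen gives a 16-fold lower number from compound 2 to compound 3 (1.21 log units; beyond the scatter), so a large gain in inhibition is possible at this position. The earlier compounds shown here offered no step between measured compounds, so they could not show this. Nothing measured here explains the size of this step.

On these data alone, it remains open whether methyl or a longer chain such as phenylethyl on this nitrogen would give a similar step. Cyclohexylmethyl in place of the added benzyl would show whether the aromatic ring matters.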